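Replacing the aryl group on the shared core: working notes

This account rests on a few compounds, and the source may have more. Where it says the series, first, only, none or still open, it means among the compounds named here.

Measured so far:
- compound 1 `COc1ccc(C(=O)/C=C/c2ccc(N(C)C)cc2)c2c1C=CC(C)(C)O2`: 570 nM
- compound 2 `COc1ccc(C(=O)/C=C/c2ccc(C(F)(F)F)cc2)c2c1C=CC(C)(C)O2`: > 10000 nM (a limit, not a number)

Among the compounds with values here, in a functional assay on SW-620 cells (Homo sapiens) for antiproliferative activity, read by MTT assay, with a stated time of 24 h (a lower number here means a stronger inhibitor, a higher number a weaker inhibitor), compound 1 gives 570 nM, the only true number so far. Compound 2 reads only as a limit: the limit of > 10000 nM in this assay, at which 1 of the 2 values shown sits.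

Next is compound 3 `COc1ccc(C(=O)/C=C/c2ccco2)c2c1C=CC(C)(C)O2`, with furan-2-yl in place of 4-(dimethylamino)phenyl on a double-bonded chain carbon bound to a double-bonded chain carbon. Within the data shown here, the one measured step bearing on this is an at least 17-fold higher number from compound 1 to compound 2 (1.24 log units; beyond the scatter), which also removes the dimethylamino group, so a large move to a higher number is expected in this assay. The expected change is a 5.3-fold higher number from compound 1 to compound 3 (0.72 log units; beyond the scatter). For compound 3 the estimate is 3000 nM, with an expected range of 800 nM to 10000 nM.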

Compound 3, half-maximal inhibitory concentration: > 10000 nM
Compound 3 was reported as a limit (the forecaster's own chance of this, stated with the estimate: 20%); at least 3.3-fold (0.52 log units) between middle value and limit.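

In this assay furan-2-yl in place of 4-(dimethylamino)phenyl gives an at least 17-fold higher number from compound 1 to compound 3 (1.24 log units; beyond the scatter) and so shows that the large move is not unique to the trifluoromethyl change. Compound 3 reads as a limit of > 10000 nM and not as a number, so no order with compound 2 can be read. Only compound 1 keeps a true number in this small set: the limit of > 10000 nM in this assay, at which 2 of the 3 values shown sit.

Still open, on these data alone, is whether the dimethylamino group or the phenyl ring carrying it matters more. An unsubstituted phenyl or a 4-aminophenyl in place of 4-(dimethylamino)phenyl would help separate the two.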